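This account rests on a few compounds, and the source may have more. Where it says the series, first, only, none or still open, it means among the compounds named here.

Series notes, step from compound 3 to compound 4.

Three compounds share the core and differ only in the five-membered ring carried on the saturated chain carbon bound to an aromatic carbon. Compound 1 `CCCCOC(=O)NS(=O)(=O)c1sc(CC(C)C)cc1-c1ccc(Cc2nccs2)cc1` gives 3.2 nM in an assay on membranes from uterus for displacement of a labelled ligand from Angiotensin type II receptor (Sus scrofa), with a stated time of 1.5 h; on this read-out higher numbers stand for weaker inhibition and lower numbers for stronger inhibition. Compound 2 `CCCCOC(=O)NS(=O)(=O)c1sc(CC(C)C)cc1-c1ccc(Cn2cccn2)cc1` gives 2.3 nM in this assay, and the step of a 1.4-fold lower number from compound 1 to compound 2 (0.14 log units; within the scatter) is within the scatter. Compound 3 `CCCCOC(=O)NS(=O)(=O)c1sc(CC(C)C)cc1-c1ccc(Cn2ncnn2)cc1` gives 16 nM in this assay and stands highest of the three numbers; the steps of a 5.0-fold higher number from compound 1 to compound 3 (0.70 log units; beyond the scatter) and a 7.0-fold higher number from compound 2 to compound 3 (0.84 log units; beyond the scatter) both lie beyond the scatter, so the 2H-tetrazol-2-yl group is the one attachment that clearly weakens binding here.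

Compound 4 `CCCCOC(=O)NS(=O)(=O)c1sc(CC(C)C)cc1-c1ccc(CN2CCN(C)C2=O)cc1` has not yet been measured in this assay. The change from compound 3 is 3-methyl-2-oxoimidazolidin-1-yl in place of 2H-tetrazol-2-yl on a saturated chain carbon bound to an aromatic carbon. Among the compounds with values here, no measured step covers a non-aromatic ring at this position; the two steps that bear on it show that moving away from the tetrazole toward either of the other rings lowered the number by a modest margin. Taking that as the guide, compound 4 is expected to return toward the range of compounds 1 and 2, the estimated step being a 3.2-fold lower number from compound 3 to compound 4 (0.51 log units; beyond the scatter). The expected value for compound 4 in this assay is 5 nM, with a range from 1.5 nM to 20 nM.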

Compound 4, inhibition constant: 16.5 nM
Estimate against measurement, compound 4: 3.3-fold (0.52 log units) below; the range from low to high includes it.
By their numbers in this assay, from the lowest: compounds 2 and 1 (each within the scatter of the next); then compounds 3 and 4 (each within the scatter of the next).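

Moving from an aromatic to a non-aromatic ring at this position does not separate the two groups in this assay, with a 1.0-fold higher number from compound 3 to compound 4 (0.01 log units; within the scatter), even though 3-methyl-2-oxoimidazolidin-1-yl differs from 2H-tetrazol-2-yl in ring type, heavy atoms and hydrogen-bond acceptors. The weaker level is no longer specific to the 2H-tetrazol-2-yl group. Compound 4 also stands apart from the two stronger compounds, with a 7.2-fold higher number from compound 2 to compound 4 (0.86 log units; beyond the scatter) and a 5.2-fold higher number from compound 1 to compound 4 (0.71 log units; beyond the scatter), both beyond the scatter. Nothing available accounts for this grouping of the four attachments on the saturated chain carbon bound to an aromatic carbon.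

With a single non-aromatic ring in the set, nothing can yet be said of such rings as a class, and the part played by the methyl group of compound 4 stays unresolved. Open, going by these compounds, is what a plain 2-oxoimidazolidin-1-yl group, or an amine such as piperidin-1-yl, would give on the same carbon of the shared core.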